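Swapping a Nitro Group for an Amide: Expected Tolerance

A few compounds are considered here, and "the series" means these few. Any claim that something is new, unique, unknown or untested is made for them only; others in the source may bear on it.

Measured so far:
Compound 1, `Cn1c(-c2ccc([N+](=O)[O-])cc2)nc2cc(C(F)(F)F)ccc21`, gives > 100000 nM in an ADME assay on MDBK cells (Bos taurus) for cytotoxicity, read by MTT assay, with a stated time of 96 h; a higher number here means that more compound is tolerated, a lower number that less compound is tolerated; that value is a limit of this assay, not a number.
Compound 2, `O=[N+]([O-])c1ccc(-c2nc3cc(C(F)(F)F)ccc3[nH]2)cc1`, gives 6000 nM.

Among the compounds with values here, compound 2 thus holds the only true number here, the other value being a limit. Within the data shown here, the one measured step, an at least 16-fold lower number from compound 1 to compound 2 (1.22 log units; beyond the scatter), concerns compound 1 sitting at the limit of > 100000 nM in this assay, at which 1 of the 2 values shown sits. Compound 3, `CCN(CC)CC(=O)Nc1ccc(-c2nc3cc(C(F)(F)F)ccc3[nH]2)cc1`, differs from compound 2 by (((diethylamino)methyl)carbonyl)amino in place of nitro on an aromatic carbon. Among the measured compounds shown here, no measured step touches this position, so the earlier step offers no direct guide. A modest shift toward more tolerance is expected, a 2.5-fold higher number from compound 2 to compound 3 (0.40 log units; beyond the scatter). Compound 3 is estimated at 15000 nM, within 4000 nM to 60000 nM.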

Compound 3, half-maximal cytotoxic concentration: 13000 nM
For compound 3 the middle estimate is 1.2-fold (0.06 log units) above the measured one, and the stated range covers the measured number.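

Placing (((diethylamino)methyl)carbonyl)amino in place of nitro, on an aromatic carbon para to a large group, gives in this assay a 2.2-fold higher number from compound 2 to compound 3 (0.34 log units; beyond the scatter). Within the data shown here, this is the first reading at this position, since the earlier step concerned only the aromatic nitrogen, and it shows that the much larger group is accepted with only a modest change in the number. Nothing shown here explains the size of this shift. Still open, on these data alone, is whether a plain amine or a carboxylic acid at this position would give a similar number. Also open, as far as these compounds go, is how a longer chain on the amide would read.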